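The source may report more compounds than this note shows. Statements on the series, on what has been measured and on what is new or still open speak of the compounds shown alone.

Measured so far:
- compound 1, `C#C[C@@]1(O)[C@@H](CO)O[C@@H](n2cnc3c(-c4ccc(Cl)cc4)ncnc32)[C@@H]1O`: 170000 nM in a functional assay on HeLa cells (Homo sapiens) for antiproliferative activity, read by cell counting, with a stated time of 72 h; a higher number here means a weaker inhibitor, a lower number a stronger inhibitor
- compound 2, `C#C[C@@]1(O)[C@@H](CO)O[C@@H](n2cc(F)c3c(N)ncnc32)[C@@H]1O`: 150 nM in this assay

Compound 2 holds the lower of the two numbers in this assay; compound 1 sits far above it, well beyond the usual scatter. The next compound, compound 3, `C#C[C@@]1(O)[C@@H](CO)O[C@@H](n2cc(Cl)c3c(N)ncnc32)[C@@H]1O`, is not yet measured. It differs from compound 2 only at one aromatic carbon of the five-membered ring: chloro in place of fluoro on an aromatic carbon. Among the measured compounds shown here, no measured pair in the set shows this change. In this assay the step from fluoro to chloro is expected to be small, a 1.5-fold lower number from compound 2 to compound 3 (0.18 log units; within the scatter), most likely within the scatter, if anything toward a lower number. Compound 3 is estimated at 100 nM, in the range 30 nM to 500 nM.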

Compound 3, half-maximal inhibitory concentration: 51 nM
For compound 3 the middle estimate is 2.0-fold (0.29 log units) above the measured one; low and high end bracket the measured number.
By their numbers in this assay, from the lowest: compound 3; then compound 2; then compound 1.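

This aromatic carbon of the five-membered ring responds to the choice of halogen: in this assay, chloro in place of fluoro gives a 2.9-fold lower number from compound 2 to compound 3 (0.47 log units; beyond the scatter), a modest step but beyond the scatter. Among the compounds shown here, this is the first single-place comparison, and it shows that chloro at this carbon carries no loss relative to fluoro. No evidence at hand bears on the origin of this step.

One step between two halogens sets no trend. Open, going by these compounds, is whether bromo, methyl or a nitrile at this carbon would extend or reverse it.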